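The source may report more compounds than this note shows. Statements on the series, on what has been measured and on what is new or still open speak of the compounds shown alone.

Working notes on the series: in an ADME assay on microsomes from liver (Mus musculus) for metabolic stability, read by LC-MS, with a stated time of 10 min, tested at 0.5 uM (a lower number here means that less of the compound is left, a higher number that more of the compound is left), compound 1 `c1ccc2c(c1)CN[C@@H](CN(CC1CCNCC1)[C@H]1CCCc3cccnc31)C2` gives 13%, compound 2 `c1ccc2c(c1)CN[C@@H](CN(CCCN1CCNCC1)[C@H]1CCCc3cccnc31)C2` gives 92% and compound 3 `c1ccc2c(c1)CN[C@@H](CN(CCCN1CCN(C3CC3)CC1)[C@H]1CCCc3cccnc31)C2` gives 3%. For compound 3, the nearest measured step is a number 10 percentage points lower from compound 1 to compound 3 (within the scatter) and the furthest is a number 89 percentage points lower from compound 2 to compound 3 (beyond the scatter).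

The next change leads to compound 4 `c1ccc2c(c1)CN[C@@H](CN(CCCCN1CCNCC1)[C@H]1CCCc3cccnc31)C2`: (piperazin-1-yl)methyl in place of 4-cyclopropylpiperazin-1-yl on a saturated chain carbon, three bonds along the chain from an amine nitrogen, on a saturated chain carbon, three bonds along the chain from an amine nitrogen. The cyclopropyl goes, so the most relevant evidence is a number 89 percentage points lower from compound 2 to compound 3 (beyond the scatter), read in reverse, alongside the large a number 79 percentage points higher from compound 1 to compound 2 (beyond the scatter). Within the data shown here, no measured step covers the chain change alone, so the range stays wide. A large upward step is expected, estimated as a number 69 percentage points higher from compound 3 to compound 4 (beyond the scatter). The expected value for compound 4 is 72%, with an estimated range of 35% to 95%.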

Compound 4, percent of the compound remaining: 96%
The estimate for compound 4 lay 24 percentage points below the measured number; the measured number lies above the stated range.
By their numbers in this assay, from the lowest: compounds 3 and 1 (each within the scatter of the next); then compounds 2 and 4 (each within the scatter of the next).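

In this assay, (piperazin-1-yl)methyl in place of 4-cyclopropylpiperazin-1-yl gives a number 93 percentage points higher from compound 3 to compound 4 (beyond the scatter), so the high value seen with the free ring amine also holds on the longer chain. At this place, (piperazin-1-yl)methyl in place of piperazin-1-yl gives a number 4 percentage points higher from compound 2 to compound 4 (within the scatter), so this added chain carbon leaves the read-out unresolved, while 3-(piperazin-1-yl)propyl in place of piperidin-4-yl gives a number 83 percentage points higher from compound 1 to compound 4 (beyond the scatter). No supporting data explain these steps.

Open, on these data alone, is how a methyl or acetyl on the ring nitrogen of compound 4 would read, and whether a still longer chain would keep the value.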